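The source may report more compounds than this note shows. Statements on the series, on what has been measured and on what is new or still open speak of the compounds shown alone.

In a functional assay on PANC-1 cells (Homo sapiens) for cytotoxicity, read by MTT assay, with a stated time of 72 h (on this read-out higher numbers stand for weaker inhibition and lower numbers for stronger inhibition), compound 3 `O=C1C(Nc2ccc(-c3ccc(F)cc3)cc2)=CC(=O)c2ncncc21` gives 3200 nM, and compound 2 `Nc1ccc(-c2ccc(NC3=CC(=O)c4ncncc4C3=O)cc2)cc1` gives 3700 nM. That gap, a 1.2-fold lower number from compound 2 to compound 3 (0.06 log units; within the scatter), lies within the scatter. Compound 1 `O=C1C(Nc2ccc(OC(F)(F)F)cc2)=CC(=O)c2ncncc21` gives 900 nM, the lowest number of the three. Compound 4 `CCOC(=O)c1ccc(NC2=CC(=O)c3ncncc3C2=O)cc1` carries ethoxycarbonyl in place of 4-fluorophenyl on an aromatic carbon, para to a large group: ethoxycarbonyl in place of 4-fluorophenyl on an aromatic carbon. Among the measured compounds shown here, no measured step involves ethoxycarbonyl. The nearest evidence is the replacement of trifluoromethoxy by a ring-bearing group, a 3.6-fold higher number from compound 1 to compound 3 (0.55 log units; beyond the scatter) and a 4.1-fold higher number from compound 1 to compound 2 (0.61 log units; beyond the scatter), both modest and beyond the scatter. A modest move in the opposite direction is therefore expected, though with little certainty. The expected step is a 2.1-fold lower number from compound 3 to compound 4 (0.33 log units; beyond the scatter). For compound 4 the estimate is 1500 nM, with an expected range of 500 nM to 4000 nM.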

Compound 4, half-maximal inhibitory concentration: 1600 nM
Beside the measured number, compound 4's estimate is 1.1-fold (0.03 log units) below it; the measured number falls inside the stated range.
By their numbers in this assay, from the lowest: compounds 1, 4, 3 and 2 (each within the scatter of the next, the first and the last beyond it).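

In this assay, a group with no ring at this position, ethoxycarbonyl, gives a 2.0-fold lower number from compound 3 to compound 4 (0.30 log units; within the scatter) and a 1.8-fold higher number from compound 1 to compound 4 (0.25 log units; within the scatter), so the ring of the 4-fluorophenyl group is not needed to keep the number in this range. Only the change from 4-aminophenyl moves the number beyond the scatter, with a 2.3-fold lower number from compound 2 to compound 4 (0.36 log units; beyond the scatter). No measurement here accounts for these steps. Still open, going by these compounds, is whether a carboxylic acid or a primary amide in place of the ester gives a similar number. Also open, on these data alone, is how a longer ester chain compares with ethoxycarbonyl.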